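Adding Dimethoxy Groups to the Outer Phenyl

The compounds below may be only part of what the source reports. "The series", "measured", "known", "first", "only" and "open" are said of these compounds alone.

Measured in a functional assay on SiHa cells (Homo sapiens) for inhibition, read by sulforhodamine B assay; a higher number here means a weaker inhibitor of growth, a lower number a stronger inhibitor of growth:
Compound 1 `c1ccc(-c2ccc(-c3ccc(-c4nc5ccccc5[nH]4)cc3)cc2)cc1`: 100000 nM
Compound 2 `Oc1ccc(-c2ccc(-c3ccc(-c4nc5ccccc5[nH]4)cc3)cc2)cc1`: 33300 nM
Compound 3 `Oc1cccc2[nH]c(-c3ccc(-c4ccc(-c5ccccc5)cc4)cc3)nc12`: 9710 nM

Of these three compounds, compound 3 has the lowest number in this assay and is the strongest inhibitor of growth. The next compound, compound 4 `COc1ccc(-c2ccc(-c3ccc(-c4nc5c(O)cccc5[nH]4)cc3)cc2)cc1OC`, keeps the hydroxy group of compound 3 and differs from it as follows: 3,4-dimethoxyphenyl in place of phenyl on an aromatic carbon. In words, 3,4-dimethoxyphenyl stands in place of phenyl on an aromatic carbon.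

Within the data shown here, two measured steps bear on this change. Hydroxy in place of hydrogen on the phenyl that changes here gave a 3.0-fold lower number from compound 1 to compound 2 (0.48 log units; beyond the scatter), a modest step and the closer guide. Hydroxy in place of hydrogen elsewhere gave a 10-fold lower number from compound 1 to compound 3 (1.01 log units; beyond the scatter), a large step, but that hydroxy is already present in compound 3. Among the measured compounds shown here, no measured compound carries a methoxy group, so the guide is only partial. A modest move toward a lower number is therefore expected, and the estimated step is a 1.9-fold lower number from compound 3 to compound 4 (0.29 log units; within the scatter). For compound 4 the estimate is 5000 nM, with an expected range from 1500 nM to 17000 nM.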

Compound 4, concentration for 50% growth inhibition: 1110 nM
Compound 4: middle estimate off by 4.5-fold (0.65 log units), on the high side, outside the stated range (below it).
By their numbers in this assay, from the lowest: compound 4; then compound 3; then compound 2; then compound 1.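

In this assay, 3,4-dimethoxyphenyl could replace the phenyl with an 8.7-fold lower number from compound 3 to compound 4 (0.94 log units; beyond the scatter), so this position accepts a larger ring substituted with methoxy groups and the number still falls. The earlier step on this ring, a 3.0-fold lower number from compound 1 to compound 2 (0.48 log units; beyond the scatter), involved a hydroxy group and a core without its own hydroxy, whereas the new step shows that a change on this ring can still lower the number when the core hydroxy is already present. Nothing measured here accounts for the size of this step.

The compounds shown leave open whether both methoxy groups are needed or one would give a similar step, and whether the same change would lower the number without the core hydroxy. They also leave open how an amine or a carboxylic acid on this phenyl would compare.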